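Replacing Thiophen-3-yl with Pyridin-3-yl on the Shared Core

The source may hold more compounds than are shown below. What is called first, only, known or untested is meant among the compounds shown, and "the series" means these compounds.

In a functional assay on HCT-15 cells (Homo sapiens) for cytotoxicity, read by ELISA, with a stated time of 2 days (on this read-out higher numbers stand for weaker inhibition and lower numbers for stronger inhibition), compound 3 (`Oc1ccc(-c2cc(-c3ccccc3)cc(-c3ccsc3)n2)cc1`) gives the lowest number of the three measured compounds at 1100 nM against compound 1 (`Oc1ccc(-c2cc(-c3ccccc3)cc(-c3ccccc3)n2)cc1`) at 3700 nM and compound 2 (`Oc1ccc(-c2cc(-c3ccccc3)cc(-c3cccs3)n2)cc1`) at 12500 nM in the same test. Compound 4 (`Oc1ccc(-c2cc(-c3ccccc3)cc(-c3cccnc3)n2)cc1`) carries pyridin-3-yl in place of thiophen-3-yl on an aromatic carbon next to the ring nitrogen (pyridin-3-yl in place of thiophen-3-yl on an aromatic carbon). Among the compounds with values here, no measured step makes this exact exchange, but three steps bear on the same carbon. Thiophen-3-yl in place of phenyl gave a 3.4-fold lower number from compound 1 to compound 3 (0.53 log units; beyond the scatter) and thiophen-2-yl in place of phenyl gave a 3.4-fold higher number from compound 1 to compound 2 (0.53 log units; beyond the scatter) while thiophen-3-yl in place of thiophen-2-yl gave an 11-fold lower number from compound 2 to compound 3 (1.06 log units; beyond the scatter) at that carbon. The number therefore moved both ways with the ring placed there. Pyridin-3-yl is six-membered like the phenyl of compound 1 at 3700 nM so a modest move back towards that number is expected. The expected change is a 3.2-fold higher number from compound 3 to compound 4 (0.50 log units; beyond the scatter) in this assay on this reasoning. For compound 4 the estimated value is 3500 nM with an expected range from 1200 nM to 10000 nM on this evidence.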

Compound 4, half-maximal inhibitory concentration: 15100 nM
Estimate against measurement, compound 4: 4.3-fold (0.63 log units) below; measured number above the stated range.
By their numbers in this assay, from the lowest: compound 3; then compound 1; then compounds 2 and 4 (each within the scatter of the next).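

At the aromatic carbon next to the ring nitrogen, pyridin-3-yl gives a 14-fold higher number from compound 3 to compound 4 (1.14 log units; beyond the scatter) in this assay and also a 4.1-fold higher number from compound 1 to compound 4 (0.61 log units; beyond the scatter), so sharing a six-membered ring with the phenyl of compound 1 did not keep the number near that of compound 1. Pyridin-3-yl in place of thiophen-2-yl gives a 1.2-fold higher number from compound 2 to compound 4 (0.08 log units; within the scatter), which leaves compound 2 and compound 4 level. Of the three rings with a hetero atom at this carbon, only the thiophen-3-yl of compound 3 gives a lower number than phenyl, while compound 2 and compound 4 go against any general gain from a hetero atom.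

Nothing shown accounts for these differences between the rings. From the compounds shown here alone, how furan-3-yl or pyridin-4-yl would read at this carbon stays open, and so does the effect of an amine on the pyridin-3-yl ring.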